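This account rests on a few compounds, and the source may have more. Where it says the series, first, only, none or still open, it means among the compounds named here.

Measured so far in a functional assay on PC-3 cells (Homo sapiens) for antiproliferative activity, read by MTT assay, tested at 5 uM; a lower number here means a weaker effect, a higher number a stronger effect of the compound at the concentration tested:
- compound 1, `COc1ccc(/C=N/NC(=O)c2cc(OC)c(OC)c(OC)c2)c(OC)c1`: 22.2%
- compound 2, `COc1cc(C2=NN(C(C)=O)C(c3c(Cl)cccc3Cl)O2)cc(OC)c1OC`: -2.2%
- compound 3, `COc1cc(C2=NN(C(C)=O)C(c3cc(Cl)cc(Cl)c3)O2)cc(OC)c1OC`: 93.9%

Compound 3 stands highest of these three numbers. Its nearest neighbour is compound 1, and compound 2 lies furthest from it; both gaps are beyond the scatter. Compound 4, `COc1cc(C2=NN(C(C)=O)C(c3cccc(OC)c3OC)O2)cc(OC)c1OC`, keeps the core of compound 3 and changes only the aryl group on the saturated ring carbon: 2,3-dimethoxyphenyl in place of 3,5-dichlorophenyl on a saturated ring carbon. Among the compounds with values here, one measured step bears on this place. It was a number 96.1 percentage points higher from compound 2 to compound 3 (beyond the scatter), which shows that swapping one aryl group for another at this ring carbon can move the read-out across almost its whole span. A sizeable step is therefore expected for compound 4 as well, most likely downward, since compound 3 already sits near the top and the only other aryl variant at this position, compound 2, gave -2.2%. The expected step is a number 53.9 percentage points lower from compound 3 to compound 4 (beyond the scatter). For compound 4 in this assay the estimate is 40%, within a range from 5% to 85%.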

Compound 4, a percentage reported as inhibition, at one concentration (the size of the read-out at that concentration, not a potency): 58.2%
Compound 4: middle estimate off by 18.2 percentage points, on the low side; the range from low to high includes it.
By their numbers in this assay, from the lowest: compound 2; then compound 1; then compound 4; then compound 3.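

In this assay, 2,3-dimethoxyphenyl at this ring carbon gives up part of the effect, with a number 35.7 percentage points lower from compound 3 to compound 4 (beyond the scatter), but it still stands well clear of the inactive 2,6-dichlorophenyl compound, with a number 60.4 percentage points higher from compound 2 to compound 4 (beyond the scatter). The position is therefore not all-or-nothing: a third aryl group gives an intermediate level, and an aryl ring carrying no chlorine keeps a clear effect, so chlorine is not required here. No measurement offered here explains these differences.

The 2,3-dimethoxyphenyl group differs from both dichlorophenyl groups in the kind of substituent and in where it sits on the ring, so these compounds cannot separate those two changes. Also open, from the compounds shown here alone, is how a plain phenyl ring, or an aryl ring bearing an amine or a carboxylic acid, would behave at this carbon.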